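Replacing the (methoxymethoxy)methyl group of compound 3

A few compounds are considered here, and "the series" means these few. Any claim that something is new, unique, unknown or untested is made for them only; others in the source may bear on it.

Measured so far in a functional assay on HL-60 cells (Homo sapiens) for antiproliferative activity, read by MTT assay, with a stated time of 48 h; on this read-out lower numbers stand for stronger inhibition and higher numbers for weaker inhibition
- compound 1 `CC(C)=CCC[C@]1(C)/C=C/[C@@H](OC(=O)C=C(C)C)[C@](C)(O)/C=C/C(=O)/C(CN(C)C)=C\C1` gives 140 nM
- compound 2 `CC(C)=CCC[C@]1(C)/C=C/[C@@H](OC(=O)C=C(C)C)[C@](C)(O)/C=C/C(=O)/C(CN2CCCC2)=C\C1` gives 160 nM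
- compound 3 `COCOC/C1=C/C[C@](C)(CCC=C(C)C)/C=C/[C@@H](OC(=O)C=C(C)C)[C@](C)(O)/C=C/C1=O` gives 2840 nM

Compound 3 has the highest number of the three. Compound 4 `CC(C)=CCC[C@]1(C)/C=C/[C@@H](OC(=O)C=C(C)C)[C@](C)(O)/C=C/C(=O)/C(C(=O)N2CCCC2)=C\C1` differs from it as follows: (pyrrolidin-1-yl)carbonyl in place of (methoxymethoxy)methyl on a double-bonded ring carbon. In words, this is (pyrrolidin-1-yl)carbonyl in place of (methoxymethoxy)methyl on a double-bonded ring carbon. Two large measured steps bear on this change: a 20-fold higher number from compound 1 to compound 3 (1.31 log units; beyond the scatter) and an 18-fold higher number from compound 2 to compound 3 (1.25 log units; beyond the scatter). The step between the two amines stays within the scatter: a 1.1-fold higher number from compound 1 to compound 2 (0.06 log units; within the scatter). For the measured compounds named here, compound 4 keeps the pyrrolidin-1-yl ring of compound 2, but joins it through a carbonyl, a link that no measured compound carries. Only a partial reversal of the large steps is therefore expected, a moderate move to a lower number in this assay. The expected change is a 3.2-fold lower number from compound 3 to compound 4 (0.50 log units; beyond the scatter). The estimate for compound 4 is 900 nM, with an expected range from 200 nM to 3500 nM.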

Compound 4, half-maximal inhibitory concentration: 12300 nM
Compound 4: the middle estimate sits 14-fold (1.14 log units) below what was measured, outside the stated range (above it).
By their numbers in this assay, from the lowest: compounds 1 and 2 (each within the scatter of the next); then compound 3; then compound 4.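

In this assay, the link on the double-bonded ring carbon matters as well as the group it carries: with the pyrrolidin-1-yl ring kept, (pyrrolidin-1-yl)carbonyl in place of (pyrrolidin-1-yl)methyl gives a 77-fold higher number from compound 2 to compound 4 (1.89 log units; beyond the scatter). The same replacement of (dimethylamino)methyl gives an 88-fold higher number from compound 1 to compound 4 (1.94 log units; beyond the scatter), and the change from (methoxymethoxy)methyl gives a 4.3-fold higher number from compound 3 to compound 4 (0.64 log units; beyond the scatter), so the pyrrolidin-1-yl ring alone does not restore the low numbers and compound 4 is the weakest of the four. No measurement on hand accounts for this loss.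

Going by these compounds, whether the low numbers need a nitrogen on a saturated chain carbon remains open: a morpholin-4-ylmethyl group, a hydroxymethyl group or a longer chain bearing the pyrrolidin-1-yl ring would test this. A (dimethylamino)carbonyl group would show whether the loss extends beyond the pyrrolidin-1-yl ring.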